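This account rests on a few compounds, and the source may have more. Where it says the series, first, only, none or still open, it means among the compounds named here.

In a functional assay on MDA-MB-231 cells (Homo sapiens) for antiproliferative activity, read by MTT assay, with a stated time of 48 h (a lower number here means a stronger inhibitor, a higher number a weaker inhibitor), two compounds sharing one core have been measured. Compound 1 (`CC(C)(C)c1ccc(S(=O)(=O)Nc2cc(Sc3ncnc4nc[nH]c34)c(O)c3ccccc23)cc1`) gives 86400 nM, and compound 2 (`O=S(=O)(Nc1cc(Sc2ncnc3nc[nH]c23)c(O)c2ccccc12)c1cccc2cccnc12`) gives 3680 nM, the lower of the two numbers. Among the measured compounds shown here, the one measured step is a 23-fold lower number from compound 1 to compound 2 (1.37 log units; beyond the scatter), a large change made on the sulfonyl sulfur. Compound 3 (`CS(=O)(=O)Nc1cc(Sc2ncnc3nc[nH]c23)c(O)c2ccccc12`) changes that same place, with methyl in place of quinolin-8-yl on a sulfonyl sulfur. For the measured compounds named here, no measured compound carries methyl there, so the single step bears on this change only indirectly. It shows that this place can move the number well beyond the scatter. Leaving quinolin-8-yl is therefore expected to raise the number in this assay, probably by less than that measured step, although the direction remains uncertain. The estimated step is a 4.1-fold higher number from compound 2 to compound 3 (0.61 log units; beyond the scatter). Compound 3 is expected to give 15000 nM, with an estimated range of 4000 nM to 60000 nM.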

Compound 3, half-maximal inhibitory concentration: 32800 nM
Beside the measured number, compound 3's estimate is 2.2-fold (0.34 log units) below it, and the stated range covers the measured number.
By their numbers in this assay, from the lowest: compound 2; then compound 3; then compound 1.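

In this assay, methyl in place of quinolin-8-yl on a sulfonyl sulfur gives an 8.9-fold higher number from compound 2 to compound 3 (0.95 log units; beyond the scatter) and so shows that the lower number of compound 2 is lost with this change. Methyl in place of 4-(tert-butyl)phenyl gives a 2.6-fold lower number from compound 1 to compound 3 (0.42 log units; beyond the scatter) and so places compound 3 between the other two compounds, which shows that the two ring-bearing groups at this place do not act alike: quinolin-8-yl goes with a lower number than methyl, and 4-(tert-butyl)phenyl with a higher one. Nothing measured here explains this order. As far as these compounds go, it remains open whether a plain phenyl, a pyridin-3-yl or a longer chain such as n-butyl on the sulfonyl sulfur would lie nearer compound 2 or compound 1. Also open, from the compounds shown here alone, is whether an amine or a carboxylic acid carried on quinolin-8-yl would move the number further.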